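The compounds below may be only part of what the source reports. "The series", "measured", "known", "first", "only" and "open" are said of these compounds alone.

Compound 1 `COc1ccc(CNc2nc([Se]C)nc3ccccc23)cc1` stands at the weak end of what is shown: in a functional assay on CCRF-CEM cells (Homo sapiens) for cytotoxicity, read by MTT assay, with a stated time of 72 h (a higher number here means a weaker inhibitor of growth, a lower number a stronger inhibitor of growth), compound 1 gives > 100000 nM, which is a limit of the assay and not a number. Compound 2 `CSc1ccc(CNc2nc([Se]C)nc3ccccc23)cc1` gives 48700 nM in this assay, and the step of an at least 2.0-fold lower number from compound 1 to compound 2 (0.31 log units; beyond the scatter) rests on (the limit of > 100000 nM in this assay, at which 1 of the 2 values shown sits). Compound 3 `COc1ccc(CNc2nc(S)nc3ccccc23)cc1` is not yet measured; it differs from compound 1 by one sulfur atom in place of a group of 2 heavy atoms (1 carbon, 1 selenium; no ring), on an aromatic carbon. Within the data shown here, no measured step touches that position, so the single measured step offers no direct guide. Compound 3 is expected near 100000 nM in this assay, within 30000 nM to 300000 nM, meaning an expected step of a number no higher from compound 1 to compound 3 (the limit leaves the size open), with a fair chance that again only a limit is reported.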

Compound 3, concentration for 50% growth inhibition: 10400 nM
Compound 3: middle estimate off by 9.6-fold (0.98 log units), on the high side; measured number outside the range, below it.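

The position between two ring nitrogen atoms responds to change in this assay, the first sign of this in the series: replacing the carbon and selenium group with sulfanyl gives an at least 9.6-fold lower number from compound 1 to compound 3 (0.98 log units; beyond the scatter). Selenium at this position is therefore not required for a measurable value, as compound 3 shows. The full size of the step stays open: the limit of > 100000 nM in this assay, at which 1 of the 3 values shown sits.

On these data alone, how an amine or a longer chain at this position would read in this assay remains open, as does whether sulfanyl keeps its effect with methylsulfanyl in place of methoxy.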